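The source may report more compounds than this note shows. Statements on the series, on what has been measured and on what is new or still open speak of the compounds shown alone.

Of the compounds shown here, three built on one shared core have been tested in an assay on striatum for inhibition of sodium-dependent dopamine transporter (Rattus norvegicus); on this read-out higher numbers stand for weaker inhibition and lower numbers for stronger inhibition. Compound 1 `COc1ccc(CN[C@@H]2CO[C@H](C(c3ccccc3)c3ccccc3)C[C@H]2O)cc1O` gives 58.6 nM. Compound 2 `Oc1ccc(CN[C@@H]2CO[C@H](C(c3ccc(F)cc3)c3ccc(F)cc3)C[C@H]2O)cc1F` gives 13.1 nM. Compound 3 `COc1ccc(CN[C@@H]2CO[C@H](C(c3ccccc3)c3ccccc3)C[C@H]2O)cn1` gives 44.1 nM, the second highest of the three numbers; compound 1 lies within the scatter of it, while compound 2 shows a lower number beyond the scatter, though no single change links those two. Compound 4 `COc1cc(CN[C@@H]2CO[C@H](C(c3ccccc3)c3ccccc3)C[C@H]2O)ccc1O` has not been measured. It differs from compound 3 in one place: 4-hydroxy-3-methoxyphenyl in place of 6-methoxypyridin-3-yl on a saturated chain carbon bound to an amine nitrogen. Within the data shown here, the only measured step at that place, a 1.3-fold lower number from compound 1 to compound 3 (0.12 log units; within the scatter), stayed within the scatter, and compound 1 carries a 3-hydroxy-4-methoxyphenyl group at the same place. The expected step of a 1.1-fold higher number from compound 3 to compound 4 (0.05 log units; within the scatter) is therefore none beyond the scatter. Compound 4 is estimated at 50 nM, between 20 nM and 150 nM, in this assay.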

Compound 4, inhibition constant: 167 nM
For compound 4 the middle estimate is 3.3-fold (0.52 log units) below the measured one; the whole stated range lies below it.
By their numbers in this assay, from the lowest: compound 2; then compounds 3 and 1 (each within the scatter of the next); then compound 4.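

In this assay the group at this place does matter: moving to 4-hydroxy-3-methoxyphenyl gives a 3.8-fold higher number from compound 3 to compound 4 (0.58 log units; beyond the scatter) and also a 2.8-fold higher number from compound 1 to compound 4 (0.45 log units; beyond the scatter). The second step only exchanges 3-hydroxy-4-methoxyphenyl for 4-hydroxy-3-methoxyphenyl, so the same hydroxy and methoxy groups, named in a different order on the ring, are enough to shift the number beyond the scatter. Nothing measured here explains this shift. Still open, going by these compounds, is how an amine or a carboxylic acid in place of the hydroxy group would behave at this place.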